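One More Chain Carbon Before the Hydroxycarbamoyl Group

This account rests on a few compounds, and the source may have more. Where it says the series, first, only, none or still open, it means among the compounds named here.

For the measured compounds named here, in a functional assay on HeLa cells (Homo sapiens) for inhibition, read by MTT assay, with a stated time of 48 h (a higher number here means a weaker inhibitor, a lower number a stronger inhibitor), compound 2 `O=C(CCCCCCOc1no[n+]([O-])c1S(=O)(=O)c1ccccc1)NO` gives 4090 nM as the only number available, whereas compound 1 `O=S(=O)(c1ccccc1)c1c(OCCCCCCO)no[n+]1[O-]` has the entry "not determined" (no result reported) and offers no comparison. Compound 2 therefore cannot be ranked against anything. Compound 3 `O=C(CCCCCCCOc1no[n+]([O-])c1S(=O)(=O)c1ccccc1)NO` differs from compound 2 by (hydroxycarbamoyl)methyl in place of hydroxycarbamoyl on a saturated chain carbon, six bonds along the chain from an oxygen on an aromatic ring and has yet to be tested. Going by the values given here, no measured step shows what such a change does, so in this assay only a slight strengthening is expected, within the scatter. The expected change is a 1.2-fold lower number from compound 2 to compound 3 (0.09 log units; within the scatter) on this reasoning. Compound 3 is estimated at 3300 nM with an expected range from 1300 nM to 8000 nM in this assay when measured.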

Compound 3, half-maximal inhibitory concentration: 5030 nM
Compound 3: the middle estimate sits 1.5-fold (0.18 log units) below what was measured; low and high end bracket the measured number.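

In this assay, for the compounds shown here, the first readable step on this chain is a 1.2-fold higher number from compound 2 to compound 3 (0.09 log units; within the scatter) and so (hydroxycarbamoyl)methyl in place of hydroxycarbamoyl at this saturated chain carbon leaves the two compounds indistinguishable. Compound 1, without a result, could not show that this one-carbon extension is tolerated here. No evidence on the compounds shown speaks to an explanation. Still open, going by these compounds, is whether 2-(hydroxycarbamoyl)ethyl or a longer chain would keep this level, and what a carboxylic acid or an amine would do in place of the hydroxycarbamoyl group.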